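This account rests on a few compounds, and the source may have more. Where it says the series, first, only, none or still open, it means among the compounds named here.

Measured so far in a functional assay on A549 cells (Homo sapiens) for antiproliferative activity, read by MTT assay; on this read-out higher numbers stand for weaker inhibition and lower numbers for stronger inhibition:
- compound 1 `COc1ccc(-c2ccnc(Nc3ccc([N+](=O)[O-])cc3)n2)cc1`: 2730 nM
- compound 2 `Clc1ccc(Nc2nccc(-c3ccc(Cl)cc3Cl)n2)c(Cl)c1`: 11600 nM

Compound 1 holds the lower of the two numbers, and the gap up to compound 2 lies beyond the scatter. Next in line is compound 3 `O=[N+]([O-])c1ccc(Nc2nccc(-c3ccc(Br)cc3)n2)cc1`, not yet measured in this assay. It differs from compound 1 by bromo in place of methoxy on an aromatic carbon, which reads as 4-methoxyphenyl to 4-bromophenyl, para to a large group. Among the measured compounds shown here, no measured pair differs in one place only, so the data give no direct size for such a step. The only hint on direction is compound 2 at 11600 nM, and it differs from compound 1 in more than one place. The expected step is a 1.5-fold higher number from compound 1 to compound 3 (0.17 log units; within the scatter), a move to a higher number that is estimated to stay within the scatter or only just clear it. For compound 3 the estimated value is 4000 nM, with an expected range of 1300 nM to 12500 nM.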

Compound 3, half-maximal inhibitory concentration: 76000 nM
The estimate for compound 3 lay 19-fold (1.28 log units) below the measured number, outside the stated range (above it).
By their numbers in this assay, from the lowest: compound 1; then compound 2; then compound 3.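

In this assay, among the compounds shown here, bromo in place of methoxy on an aromatic carbon, para to a large group, is the first change made in one place only, and it gives a 28-fold higher number from compound 1 to compound 3 (1.44 log units; beyond the scatter). This position is therefore sensitive to the group it carries: of the two groups compared here, methoxy goes with the lower number, and the step lies well beyond the scatter. Nothing available bears on the reason for a step of this size.

On these data alone, this single pair does not separate an effect of adding bromo from one of removing methoxy, and how a hydroxy group, an amine or a longer alkoxy chain would read at this place remains open. Also open, as far as these compounds go, is whether the step keeps its size when the nitro group elsewhere in compound 1 is replaced.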